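Adding a hydroxy group to compound 1

This account rests on a few compounds, and the source may have more. Where it says the series, first, only, none or still open, it means among the compounds named here.

Within the data shown here, in a functional assay on A549 cells (Homo sapiens) for inhibition (a lower number here means a stronger inhibitor of growth, a higher number a weaker inhibitor of growth), compound 1 (`COc1ccc(-n2cnnc2-c2cc(OC)c(OC)c(OC)c2)cc1`) gives 8320 nM, the higher of the two numbers so far, which makes it the weaker growth inhibitor of the pair. Compound 2 (`COc1cc(-c2nncn2-c2ccc(N(C)C)cc2)cc(OC)c1OC`) gives 398 nM. Compound 3 (`COc1ccc(-n2cnnc2-c2cc(OC)c(OC)c(OC)c2)cc1O`) is compound 1 with one addition: hydroxy in place of hydrogen on an aromatic carbon. The new hydroxy is ortho to a methoxy group. Among the measured compounds shown here, only one measured step bears on this change: a 21-fold lower number from compound 1 to compound 2 (1.32 log units; beyond the scatter), which has dimethylamino in place of methoxy on an aromatic carbon. For the measured compounds named here, that step is large, but it involves a different group, so it shows only that a change on an aromatic carbon of compound 1 can shift the number strongly. A smaller shift in the same direction is therefore expected in this assay, with wide uncertainty. The estimate amounts to an 8.3-fold lower number from compound 1 to compound 3 (0.92 log units; beyond the scatter). Compound 3 is estimated at 1000 nM, with a range of 100 nM to 8000 nM.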

Compound 3, concentration for 50% growth inhibition: 1000 nM
The estimate for compound 3 equals the measured number at the digits printed; the measured number falls inside the stated range.
By their numbers in this assay, from the lowest: compound 2; then compound 3; then compound 1.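

Adding a single hydroxy group gives an 8.3-fold lower number from compound 1 to compound 3 (0.92 log units; beyond the scatter) in this assay, so a ring carbon that carries only hydrogen in compound 1, ortho to a methoxy group, is also a place where a change moves the number beyond the scatter. The earlier step replaced a group already on the ring, whereas here the methoxy stays in place and a group of 1 heavy atom is added to another carbon of the same ring. No measurement at hand explains this shift.

Still open, from the compounds shown here alone, is whether the hydroxy itself matters, or whether an amine, a fluorine atom or another methoxy on the same carbon would give a similar number. Also open, going by these compounds, is how this hydroxy would behave on a compound that carries the dimethylamino group of compound 2.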